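From Carboxy to Carbamoyl: An Expected Value

A few compounds are considered here, and "the series" means these few. Any claim that something is new, unique, unknown or untested is made for them only; others in the source may bear on it.

Compound 1 `CN1CCN(c2ccc(Nc3nc(-c4cccc(NC(=O)c5cccc(F)c5)c4)sc3C(=O)O)cc2)CC1`: 82.7%
Compound 2 `CN1CCN(c2ccc(Nc3nc(-c4cccc(NC(=O)c5ccc(Cl)cc5)c4)sc3C(=O)O)cc2)CC1`: 71.6%

In a functional assay on Ramos cells (Homo sapiens) for antiproliferative activity, read by CCK-8 assay, with a stated time of 72 h, tested at 40 uM (on this read-out lower numbers stand for less inhibition and higher numbers for more inhibition at the one concentration tested (going by the name of the read-out)), compound 2 gives 71.6%, the lower of the two measured numbers, while compound 1 gives 82.7%. Within the data shown here, the only measured step, a number 11.1 percentage points lower from compound 1 to compound 2 (beyond the scatter), alters a different part of the structure and says nothing about the change at hand. Compound 3 `CN1CCN(c2ccc(Nc3nc(-c4cccc(NC(=O)c5ccc(Cl)cc5)c4)sc3C(N)=O)cc2)CC1` differs from compound 2 by amino in place of hydroxy on a carbonyl carbon. Among the measured compounds shown here, with no step bearing on this change, the size and direction are unknown, and compound 3 is therefore expected to lie near compound 2, with a wide range: an estimated 68% between 45% and 85%, a step of a number 3.6 percentage points lower from compound 2 to compound 3 (within the scatter) expected to remain within the scatter.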

Compound 3, a percentage reported as inhibition, at one concentration (the size of the read-out at that concentration, not a potency): 99%
For compound 3 the middle estimate is 31 percentage points below the measured one, outside the stated range (above it).
By their numbers in this assay, from the lowest: compound 2; then compound 1; then compound 3.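

In this assay, the change from carboxy to carbamoyl gives a number 27.4 percentage points higher from compound 2 to compound 3 (beyond the scatter), so the group on this carbonyl carbon clearly matters, even though hydroxy and amino match in the heavy-atom and hydrogen-bond counts computed for them. Among these compounds, this is the first measured step at this position, and it runs upward. Nothing available explains the size of this step. From the compounds shown here alone, it remains open whether the carbamoyl gives a similar step when 3-fluorophenyl replaces 4-chlorophenyl on the other carbonyl carbon. Going by these compounds, how a methyl ester or an N-methyl amide would read at this position also remains open.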